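Aryl swap on the shared core: estimate for compound 4

The source may hold more compounds than are shown below. What is called first, only, known or untested is meant among the compounds shown, and "the series" means these compounds.

Measured so far in a functional assay on the whole organism (strain Wistar albino) for inhibition, with Rattus norvegicus as the target, read by paw edema, with stated times of 30 min and 1 h, at a dose of 50 mg/kg by the oral route; a higher number here means more inhibition at the dose given (going by the name of the read-out), a lower number less inhibition:
compound 1 `NS(=O)(=O)c1ccc2nc(-n3nc(C(F)(F)F)cc3-c3ccc(Cl)cc3)sc2c1` gives 44%
compound 2 `NS(=O)(=O)c1ccc2nc(-n3nc(C(F)(F)F)cc3-c3ccco3)sc2c1` gives 27%
compound 3 `NS(=O)(=O)c1ccc2nc(-n3nc(C(F)(F)F)cc3-c3ccc4ccccc4c3)sc2c1` gives 30%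

Compound 3 stands second highest of the three numbers: a number 3 percentage points higher from compound 2 to compound 3 (within the scatter), while a number 14 percentage points lower from compound 1 to compound 3 (beyond the scatter). Compound 4 `NS(=O)(=O)c1ccc2nc(-n3nc(C(F)(F)F)cc3-c3cccs3)sc2c1` differs from compound 3 by thiophen-2-yl in place of naphthalen-2-yl on an aromatic carbon.

For the measured compounds named here, the steps that bear on this change are a number 17 percentage points lower from compound 1 to compound 2 (beyond the scatter) and a number 14 percentage points lower from compound 1 to compound 3 (beyond the scatter), both modest drops from the 4-chlorophenyl compound, and between the two other aryl groups a number 3 percentage points higher from compound 2 to compound 3 (within the scatter). Exchanging naphthalen-2-yl for another five-membered aromatic ring is thus expected to give no step beyond the scatter, and a number 2 percentage points lower from compound 3 to compound 4 (within the scatter) is the estimated step. Compound 4 is expected to give about 28%, between 15% and 41%.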

Compound 4, a percentage reported as inhibition, in the whole organism at one dose (the size of the read-out at that dose, not a potency): 5%
Compound 4: middle estimate off by 23 percentage points, on the high side; the measured number lies below the stated range.
By their numbers in this assay, from the lowest: compound 4; then compounds 2 and 3 (each within the scatter of the next); then compound 1.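

In this assay, thiophen-2-yl in place of furan-2-yl gives a number 22 percentage points lower from compound 2 to compound 4 (beyond the scatter), so this position separates two five-membered aromatic rings that differ only in their hetero atom, whereas furan-2-yl and naphthalen-2-yl had not separated beyond the scatter. Thiophen-2-yl also sits apart from the larger groups, with a number 25 percentage points lower from compound 3 to compound 4 (beyond the scatter) and a number 39 percentage points lower from compound 1 to compound 4 (beyond the scatter), so group size alone does not order the series. No available measurement accounts for this drop.

Open, from the compounds shown here alone, is whether unsubstituted phenyl or 4-methoxyphenyl would stay close to the 4-chlorophenyl compound. Also open, going by these compounds, is whether a methyl or chloro group on the thiophene ring would restore inhibition.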